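The source may hold more compounds than are shown below. What is called first, only, known or untested is meant among the compounds shown, and "the series" means these compounds.

In a functional assay on HepG2 cells (Homo sapiens) for inhibition, read by MTT assay, with a stated time of 120 h (on this read-out lower numbers stand for stronger inhibition and higher numbers for weaker inhibition), compound 1 `CNC(=O)/C=C/c1ccc(NC(=O)Nc2ccc(Cl)c(C(F)(F)F)c2)cc1` gives 20400 nM and compound 2 `CC(NC(=O)C#Cc1ccc(NC(=O)Nc2ccc(Cl)c(C(F)(F)F)c2)cc1)c1ccccc1` gives 20500 nM, two values within the usual scatter of each other. Compound 3 `O=C(CCc1ccc(NC(=O)Nc2ccc(Cl)c(C(F)(F)F)c2)cc1)NC1CCC1` gives > 50000 nM, which is a limit of the assay and not a number. Compound 3 therefore stands at the limit of > 50000 nM in this assay, at which 1 of the 3 values shown sits, and its true position on the scale is not known.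

The next compound, compound 4 `CNC(=O)C#Cc1ccc(NC(=O)Nc2ccc(Cl)c(C(F)(F)F)c2)cc1`, differs from compound 3 in a single place: 2-(methylcarbamoyl)ethynyl in place of 2-(cyclobutylcarbamoyl)ethyl on an aromatic carbon. In words, 2-(methylcarbamoyl)ethynyl takes the place of 2-(cyclobutylcarbamoyl)ethyl on an aromatic carbon, para to a large group.

Among the compounds with values here, one measured step bears directly on this change. It has the same kind of exchange in the opposite sense, and it shows an at least 2.4-fold higher number from compound 1 to compound 3 (0.38 log units; beyond the scatter). Compound 4 keeps the 2-(methylcarbamoyl) part found in compound 1, which gives 20400 nM, and has a triple bond like compound 2, which gives 20500 nM. Undoing the change seen in that step should therefore bring the number down in this assay, although the limit leaves the size open. The estimate means an at least 2.5-fold lower number from compound 3 to compound 4 (0.39 log units; beyond the scatter), an expected move to a lower number of about the size of the measured step. For compound 4 the expected value is 20000 nM, with an estimated range from 9000 nM to 45000 nM.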

Compound 4, half-maximal inhibitory concentration: 23300 nM
Estimate against measurement, compound 4: 1.2-fold (0.07 log units) below, and the stated range covers the measured number.
By their numbers in this assay, from the lowest: compounds 1, 2 and 4 (each within the scatter of the next). At a limit, above all of these: compound 3.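

In this assay, replacing 2-(methylcarbamoyl)ethenyl with 2-(methylcarbamoyl)ethynyl on an aromatic carbon, para to a large group, gives a 1.1-fold higher number from compound 1 to compound 4 (0.06 log units; within the scatter), so this pair does not separate the double-bond and triple-bond forms of the chain. With the triple bond kept, placing methyl instead of 1-phenylethyl on the amide-type nitrogen gives a 1.1-fold higher number from compound 2 to compound 4 (0.06 log units; within the scatter), so the small methyl and the larger 1-phenylethyl are not separated here either. Only the exchange with 2-(cyclobutylcarbamoyl)ethyl gives a step beyond the scatter, an at least 2.1-fold lower number from compound 3 to compound 4 (0.33 log units; beyond the scatter), and this step changes the chain and the group on the amide nitrogen together, so it cannot assign the difference to either part.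

The value of compound 3 is a limit, which leaves the full size of that step unknown: the limit of > 50000 nM in this assay, at which 1 of the 4 values shown sits.

As far as these compounds go, it remains open whether the ethyl chain or the cyclobutyl group accounts for the step, and how a methyl amide on an ethyl chain, a cyclobutyl amide on a triple-bond chain, or a carboxylic acid or nitrile at this position would read in this assay.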